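Methyl on the benzoyl ring: expectation for compound 3

This account rests on a few compounds, and the source may have more. Where it says the series, first, only, none or still open, it means among the compounds named here.

Compound 1 `Cc1cc(C(=O)c2ccccc2)ccc1OCC(=O)Nc1nc(-c2ccccc2)cs1` and compound 2 `COc1ccc(-c2csc(NC(=O)COc3ccc(C(=O)c4ccccc4)cc3C)n2)cc1` share one core, and compound 3 `Cc1cc(C(=O)c2ccccc2C)ccc1OCC(=O)Nc1nc(-c2ccccc2)cs1` is the third member of the set. For the measured compounds named here, in a functional assay on Ehrlich cells (Mus musculus) for cytotoxicity, read by trypan blue exclusion, with a stated time of 48 h (a higher number here means a weaker inhibitor, a lower number a stronger inhibitor), compound 1 gives 22300 nM, one of only two numbers so far, and compound 2 gives 27100 nM, within the scatter of compound 1. Going by the values given here, the single measured step, a 1.2-fold higher number from compound 1 to compound 2 (0.08 log units; within the scatter), is methoxy in place of hydrogen on an aromatic carbon and sits on a different ring of the core than the change now considered. From compound 1 to compound 3 the change is methyl in place of hydrogen on an aromatic carbon, on the benzoyl side of the core. Among the compounds with values here, no measured step bears on this position; the one step available gives no reason to expect a shift in this assay beyond the scatter in either direction. Compound 3 is therefore expected at 22000 nM in this assay, within 8000 nM to 60000 nM. The expected step of a 1.0-fold lower number from compound 1 to compound 3 (0.01 log units; within the scatter) is estimated as none beyond the scatter.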

Compound 3, half-maximal inhibitory concentration: 24300 nM
For compound 3 the middle estimate is 1.1-fold (0.04 log units) below the measured one, within the range that was stated.
By their numbers in this assay, from the lowest: compounds 1, 3 and 2 (each within the scatter of the next).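

In this assay, for the compounds shown here, the first change on the benzoyl side, phenyl to 2-methylphenyl, gives a 1.1-fold higher number from compound 1 to compound 3 (0.04 log units; within the scatter) and so shows that a methyl on this aromatic carbon, ortho to a large group, is accepted with no shift that can be told from the scatter. With the methoxy change, a 1.2-fold higher number from compound 1 to compound 2 (0.08 log units; within the scatter), this makes two single changes on two different rings of the core, and neither moves the number beyond the scatter. Nothing available speaks to why this position shows no shift.

Open, as far as these compounds go, is whether this position responds to anything other than methyl: an amine or a carboxylic acid on the same carbon could still move the number. From the compounds shown here alone, whether a longer chain such as propyl stays within the scatter also remains open.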